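An Ethoxy Group Enters Compound 2: What to Expect

A few compounds are considered here, and "the series" means these few. Any claim that something is new, unique, unknown or untested is made for them only; others in the source may bear on it.

Of the compounds shown here, three built on a shared core have been measured. Compound 1 `C#CCOc1cccc(-c2cc(-c3cccc(OCC#C)c3)nc(N)n2)c1` gives 22100 nM in an assay on BTI-TN-5B1-4 cells for inhibition of Amine oxidase [flavin-containing] B (Homo sapiens), read by fluorescence and Amplex Red, using microsomes, with a stated time of 30 min; a higher number here means a weaker inhibitor, a lower number a stronger inhibitor. Compound 2 `C#CCOc1ccc(-c2cc(-c3ccc(OCC#C)cc3)nc(C)n2)cc1` gives 7830 nM in this assay, and compound 3 `C#CCOc1ccc(-c2cc(-c3ccc(OCC#C)cc3)nc(N)n2)cc1` gives 3300 nM. Compound 2 thus stands second highest of the three numbers: the nearest of the others is reached by a 2.4-fold lower number from compound 2 to compound 3 (0.38 log units; beyond the scatter), while the furthest, that of compound 1, is the higher one. Going by the values given here, that single-point step concerns amino in place of methyl on the core and is the only one-place change among the measured compounds.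

Compound 4 `C#CCOc1ccc(-c2cc(-c3ccc(OCC#C)c(OCC)c3)nc(C)n2)cc1` differs from compound 2 by ethoxy in place of hydrogen on an aromatic carbon. No measured step concerns adding a group of this kind in this place, so the data give no direction for the change. The account therefore expects a step within the scatter, a 1.0-fold lower number from compound 2 to compound 4 (0.00 log units; within the scatter), for compound 4. Compound 4 is estimated at 7800 nM, with a range from 2500 nM to 25000 nM.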

Compound 4, half-maximal inhibitory concentration: 11000 nM
For compound 4 the middle estimate is 1.4-fold (0.15 log units) below the measured one, within the range that was stated.
By their numbers in this assay, from the lowest: compound 3; then compounds 2, 4 and 1 (each within the scatter of the next, the first and the last beyond it).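

In this assay, ethoxy in place of hydrogen on an aromatic carbon, ortho to a propargyloxy group, gives a 1.4-fold higher number from compound 2 to compound 4 (0.15 log units; within the scatter) and so stays within the scatter. Going by these compounds alone, no earlier step concerned this place, and this one shows that, with methyl on the core, an ethoxy group can stand here on the six-membered aromatic ring of carbon only without a step beyond the scatter in this assay. Nothing measured among the data shown explains the size of this step.

Going by these compounds, whether a methoxy group, a fluorine atom or a longer propoxy chain in this place would give a step of similar size remains open. Also open, on these data alone, is whether ethoxy would give a similar step on compound 3, which carries amino in place of methyl on the core.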